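A few compounds are considered here, and "the series" means these few. Any claim that something is new, unique, unknown or untested is made for them only; others in the source may bear on it.

Compound 1 `C[C@@H]1O[C@H]([C@@H]2CCCN2C)C[S@@+]1[O-]` gives in an assay on CHO cells for binding affinity to muscarinic acetylcholine receptor M5 (Homo sapiens); on this read-out lower numbers stand for stronger inhibition and higher numbers for weaker inhibition < 100000 nM, a limit of the assay and not a number.
Compound 2 `C[C@H]1O[C@@H]([C@H]2CCCN2C)C[S@+]1[O-]` gives in this assay < 100000 nM, again a limit of the assay.
Compound 3 `C[C@H]1O[C@@H]([C@H]2CCCN2C)C[S@@+]1[O-]` gives in this assay < 100000 nM, also a limit of the assay.

Compound 3 therefore stands at a limit, and so do the two other measured compounds (the limit of < 100000 nM in this assay, at which 3 of the 3 values shown sit); none of the three has a number of its own. The steps between them, which differ only in configuration as drawn the fact that compounds 1 and 2 differ only in the configuration as drawn the fact that compounds 1 and 3 differ only in the configuration as drawn (the fact that compounds 2 and 3 differ only in the configuration as drawn), are all unreadable: a step that the two limits leave unreadable from compound 1 to compound 2, a step that the two limits leave unreadable from compound 1 to compound 3 and a step that the two limits leave unreadable from compound 2 to compound 3.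

Compound 4 `C[C@@H]1O[C@H]([C@@H]2CCCN2C)C[S@+]1[O-]` relates to compound 3 as follows: the two compounds have the same atoms and bonds and differ only in configuration as drawn: 4 of 4 stereo elements differ (all stereocentres are inverted: mirror images); a stereocentre at a saturated ring carbon is drawn S in compound 3 and R in compound 4; a stereocentre at a saturated ring carbon is drawn S in compound 3 and R in compound 4; a stereocentre at a saturated ring carbon is drawn R in compound 3 and S in compound 4; a stereocentre at a sulfur is drawn R in compound 3 and S in compound 4. The closest measured model is the other mirror-image pair, whose step is a step that the two limits leave unreadable from compound 1 to compound 2, which gives no readable size and no direction. With every value sitting at the same limit, no step beyond the scatter can be read from the data, and none is expected in this assay for the change to compound 4.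

Compound 4 is therefore estimated at 60000 nM, in a range from 5000 nM to 100000 nM, and the step to it, a step that the limit leaves unreadable from compound 3 to compound 4, is expected to be no more than the scatter, with the result most likely reported again only as a limit.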

Compound 4, inhibition constant: < 100000 nM
Compound 4: only a limit was reported; the forecaster's own chance of this, stated with the estimate: 85%; the middle value does not contradict the limit.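

In this assay compound 4 gives < 100000 nM, a limit of the assay and not a number. Its steps to compound 1, compound 2 and compound 3 therefore cannot be read, as all four sit at one limit: the limit of < 100000 nM in this assay, at which 4 of the 4 values shown sit.

The compounds shown leave open what number each compound would have and whether configuration changes it at all in this assay.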